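Working notes: methyl to ethyl, compound 3 to compound 4

This account rests on a few compounds, and the source may have more. Where it says the series, first, only, none or still open, it means among the compounds named here.

Measured in an ADME assay for permeability, using PAMPA, at pH 7.4 (on this read-out lower numbers stand for lower permeability and higher numbers for higher permeability), so far:
- compound 1 `CN(C[C@H]1Cc2c(cccc2N2CCN(C3CC3)CC2)CN1)[C@H]1CCCc2cccnc21` gives 265 nm/s
- compound 2 `CC(C)N1CCN(c2cccc3c2C[C@H](CN(C)[C@H]2CCCc4cccnc42)NC3)CC1` gives 143 nm/s
- compound 3 `CN1CCN(c2cccc3c2C[C@H](CN(C)[C@H]2CCCc4cccnc42)NC3)CC1` gives 996 nm/s

Of these three, compound 3 stands highest. Compound 4 `CCN1CCN(c2cccc3c2C[C@H](CN(C)[C@H]2CCCc4cccnc42)NC3)CC1` differs from it by methyl in place of hydrogen on a saturated chain carbon bound to an amine nitrogen in a ring, so 4-methylpiperazin-1-yl becomes 4-ethylpiperazin-1-yl.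

Three steps at that same nitrogen bear on this. The change to methyl gave a 3.8-fold higher number from compound 1 to compound 3 (0.58 log units; beyond the scatter) and also a 7.0-fold higher number from compound 2 to compound 3 (0.84 log units; beyond the scatter), while a 1.9-fold lower number from compound 1 to compound 2 (0.27 log units; within the scatter). Leaving methyl is therefore expected to lower the number in this assay by a modest amount. The expected change is a 2.6-fold lower number from compound 3 to compound 4 (0.42 log units; beyond the scatter) and no larger than the gap seen with compound 2. For compound 4 the estimated value is 380 nm/s, within an expected range of 150 nm/s to 850 nm/s for this measurement.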

Compound 4, apparent permeability: 205 nm/s
Compound 4: the middle estimate sits 1.9-fold (0.27 log units) above what was measured; the measured number falls inside the stated range.
By their numbers in this assay, from the lowest: compounds 2, 4 and 1 (each within the scatter of the next); then compound 3.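

Working notes on the series: in this assay, going from 4-methylpiperazin-1-yl to 4-ethylpiperazin-1-yl gives a 4.9-fold lower number from compound 3 to compound 4 (0.69 log units; beyond the scatter), so one added methyl on the saturated chain carbon already counts at this amine nitrogen in a ring. With a 1.4-fold higher number from compound 2 to compound 4 (0.16 log units; within the scatter) and a 1.3-fold lower number from compound 1 to compound 4 (0.11 log units; within the scatter), ethyl, isopropyl and cyclopropyl show no order among themselves, and only the methyl of compound 3 stands apart. No measurement on hand accounts for this step. Open, going by these compounds, is whether a hydrogen, a 2-hydroxyethyl group or a longer chain on that nitrogen would read with compound 3 or with compound 4.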